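The compounds below may be only part of what the source reports. "The series", "measured", "known", "first", "only" and "open" are said of these compounds alone.

The measured compounds:
compound 1, `Cc1cc(C#N)cc(C)c1Oc1ccnc(S(=O)(=O)CC(=O)Nc2ccccc2)n1`, 29300 nM;
compound 2, `Cc1ccc(NC(=O)CS(=O)(=O)c2nccc(Oc3c(C)cc(C#N)cc3C)n2)cc1`, 7490 nM;
compound 3, `Cc1cc(C#N)cc(C)c1Oc1ccnc(S(=O)(=O)CC(=O)Nc2ccc(Cl)cc2)n1`, 16600 nM.

All three share one core and differ only in the group carried on the amide-type nitrogen. In an ADME assay on MT4 cells (Homo sapiens) for cytotoxicity, read by MTT assay, with a stated time of 4 days (a lower number here means that less compound is tolerated, a higher number that more compound is tolerated), compound 1 stands highest of the three numbers. The nearer of its two measured steps runs a 1.8-fold lower number from compound 1 to compound 3 (0.25 log units; within the scatter), and the further one runs a 3.9-fold lower number from compound 1 to compound 2 (0.59 log units; beyond the scatter). The remaining pair differs as a 2.2-fold higher number from compound 2 to compound 3 (0.35 log units; beyond the scatter).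

Compound 4, `Cc1cc(C#N)cc(C)c1Oc1ccnc(S(=O)(=O)CC(=O)Nc2ccc(C#N)cc2F)n1`, has not yet been measured in this assay. It differs from compound 1 in one place: 4-cyano-2-fluorophenyl in place of phenyl on an amide-type nitrogen. Both measured steps away from compound 1 also put a group onto that phenyl, and each lowered the number, one modestly and one within the scatter. Going by the values given here, two groups entering at once has no direct precedent here, so the expectation rests on those two steps alone: a lower number than compound 1 is expected, most likely a modest step rather than a large one. Compound 4 is therefore estimated at 15000 nM, with a range from 5000 nM to 40000 nM. The expected step is a 2.0-fold lower number from compound 1 to compound 4 (0.29 log units; within the scatter).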

Compound 4, half-maximal cytotoxic concentration: > 268000 nM
Compound 4: a limit, no number; the forecaster's own chance of this, stated with the estimate: 10%; middle value at least 17-fold (1.25 log units) away from the limit.
By their numbers in this assay, from the lowest: compound 2; then compounds 3 and 1 (each within the scatter of the next). At a limit, above all of these: compound 4.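

The reading for compound 4 in this assay is a limit of the assay and not a number: the limit of > 268000 nM in this assay, at which 1 of the 4 values shown sits. The earlier compounds shown here showed this position only with the number falling or staying within the scatter, whereas 4-cyano-2-fluorophenyl on the amide-type nitrogen moves it the other way, with an at least 9.1-fold higher number from compound 1 to compound 4 (0.96 log units; beyond the scatter). The distance is greater still against the 4-chlorophenyl and 4-methylphenyl groups, with an at least 16-fold higher number from compound 3 to compound 4 (1.20 log units; beyond the scatter) and an at least 35-fold higher number from compound 2 to compound 4 (1.55 log units; beyond the scatter), so the group on this nitrogen spans a much wider range than compounds 1, 2 and 3 showed among themselves.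

As far as these compounds go, the cyano and fluoro groups entered together, so it stays open whether one of them alone carries this step or whether it takes both. Also open, from the compounds shown here alone, is how the number would respond to an amine or a carboxylic acid on that phenyl, or to a longer alkyl chain in place of the phenyl on the amide-type nitrogen.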